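Three limits, one open step towards compound 4

A few compounds are considered here, and "the series" means these few. Any claim that something is new, unique, unknown or untested is made for them only; others in the source may bear on it.

Measured in a physicochemical assay for solubility, in phosphate buffer, at pH 7.4; on this read-out higher numbers stand for higher solubility and lower numbers for lower solubility:
- Compound 1 `CCOC(=O)c1c(-c2ccc(Cl)cc2)[nH]c2cccc(OC)c2c1=O`: > 100000 nM, a limit
- Compound 2 `CCOC(=O)c1c(-c2ccccc2C)[nH]c2cccc(OC)c2c1=O`: > 100000 nM, a limit
- Compound 3 `CCOC(=O)c1c(-c2cccc(OC)c2)[nH]c2cccc(OC)c2c1=O`: > 100000 nM, a limit

Compound 3 has no number of its own, only the limit > 100000 nM. It shares this position with the other two compounds, as the limit of > 100000 nM in this assay, at which 3 of the 3 values shown sit, shows. The next compound, compound 4 `CCOC(=O)c1c(-c2ccc(Cl)c(Cl)c2)[nH]c2cccc(OC)c2c1=O`, carries 3,4-dichlorophenyl in place of 3-methoxyphenyl on an aromatic carbon, next to the ring nitrogen: 3,4-dichlorophenyl in place of 3-methoxyphenyl on an aromatic carbon.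

Going by the values given here, three measured steps bear on this change: a step that the two limits leave unreadable from compound 1 to compound 2, a step that the two limits leave unreadable from compound 1 to compound 3 and a step that the two limits leave unreadable from compound 2 to compound 3. None of them gives a size or a direction, so no step beyond the scatter can be expected from them. The closest guide is compound 1, which keeps a chlorine-bearing phenyl group and has the limit > 100000 nM. The expected result is a number no higher from compound 3 to compound 4 (the limit leaves the size open), and a further limit is the likeliest report. The estimate for compound 4 is 100000 nM, with an expected range of 30000 nM to 150000 nM.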

Compound 4, solubility: 39000 nM
Estimate against measurement, compound 4: 2.6-fold (0.41 log units) above; low and high end bracket the measured number.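

The steps among the three earlier compounds could not be read, but in this assay this position now shows a change that can: 3,4-dichlorophenyl in place of 3-methoxyphenyl gives an at least 2.5-fold lower number from compound 3 to compound 4 (0.40 log units; beyond the scatter), and in place of 2-methylphenyl it gives an at least 2.5-fold lower number from compound 2 to compound 4 (0.40 log units; beyond the scatter). The narrowest comparison is with the 4-chlorophenyl group, where chloro in place of hydrogen on an aromatic carbon gives an at least 2.5-fold lower number from compound 1 to compound 4 (0.40 log units; beyond the scatter), so this single added chloro group is enough to separate the two compounds. Each step has a limit at one end and so gives only a minimum size, and compound 4 alone has a number of its own: the limit of > 100000 nM in this assay, at which 3 of the 4 values shown sit.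

From the compounds shown here alone, how far the other three compounds lie from compound 4 remains open. So does what an amine on the phenyl group, or a carboxylic acid in place of the ethoxycarbonyl group, would do to the number.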